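Methoxy to hydroxy on the aryl group of compound 3

The source may hold more compounds than are shown below. What is called first, only, known or untested is meant among the compounds shown, and "the series" means these compounds.

Compound 1 `C1=C(c2cc3ccccc3o2)C2CCN1CC2`, compound 2 `C1=C(c2coc3ccccc23)C2CCN1CC2` and compound 3 `COc1ccccc1C1=CN2CCC1CC2` share one core and differ only in the aromatic group attached to it. In an assay on isolated protein for displacement of a labelled ligand from muscarinic acetylcholine receptor M3 (Cavia porcellus) (on this read-out higher numbers stand for weaker inhibition and lower numbers for stronger inhibition), compound 1 gives 59 nM, compound 2 gives 160 nM and compound 3 gives 740 nM. Compound 3 thus stands at the highest number of the three, with its gaps to compound 2 and to compound 1 both beyond the usual scatter. Compound 4 `Oc1ccccc1C1=CN2CCC1CC2` differs from compound 3 by hydrogen in place of methyl on an oxygen on an aromatic ring. Going by the values given here, no measured pair shows that change, so no step size can be read off for it. The step from compound 3 to compound 4 is expected to be a 1.2-fold higher number from compound 3 to compound 4 (0.09 log units; within the scatter), that is, none beyond the scatter. Compound 4 is therefore estimated at 900 nM, in a range from 300 nM to 3000 nM.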

Compound 4, inhibition constant: 1400 nM
For compound 4 the middle estimate is 1.6-fold (0.19 log units) below the measured one; measured number inside the range.
By their numbers in this assay, from the lowest: compound 1; then compound 2; then compounds 3 and 4 (each within the scatter of the next).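

In this assay, going by these compounds alone, the change from methoxy to hydroxy on the aromatic ring reads as a 1.9-fold higher number from compound 3 to compound 4 (0.28 log units; within the scatter) and so gives the first step for this change. At this position, hydrogen in place of methyl on the oxygen leaves no difference beyond the scatter, so the two groups cannot be told apart on this read-out. No measurement shown bears on the reason for this result.

Going by these compounds, whether a longer chain on this oxygen, such as ethoxy, or an amine in place of the hydroxy would shift the number beyond the scatter stays open. On these data alone, the effect of methoxy to hydroxy at other places on the aromatic ring also stays open.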